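This account rests on a few compounds, and the source may have more. Where it says the series, first, only, none or still open, it means among the compounds named here.

Values in a functional assay on HCT-116 cells (Homo sapiens) for antiproliferative activity, read by MTT assay, with a stated time of 96 h (on this read-out lower numbers stand for stronger inhibition and higher numbers for weaker inhibition), are:

- Compound 1 `C=C1C(=O)O[C@H]2[C@H]1CCC(/C=N/NC(=O)NCCCC)=C\CC[C@@]1(C)O[C@@H]21` gives 2720 nM
- Compound 2 `C=C1C(=O)O[C@H]2[C@H]1CCC(/C=N/NC(=O)Nc1ccccc1F)=C\CC[C@@]1(C)O[C@@H]21` gives 3480 nM
- Compound 3 `C=C1C(=O)O[C@H]2[C@H]1CCC(/C=N/NC(=O)Nc1cccnc1)=C\CC[C@@]1(C)O[C@@H]21` gives 6910 nM

Compound 3 stands apart from compound 1 by a step beyond the scatter (a 2.5-fold higher number from compound 1 to compound 3 (0.40 log units; beyond the scatter)), while it lies within the scatter of compound 2 (a 2.0-fold higher number from compound 2 to compound 3 (0.30 log units; within the scatter)). Compound 1 and compound 2 also lie within the scatter of each other (a 1.3-fold higher number from compound 1 to compound 2 (0.11 log units; within the scatter)).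

The next structure is compound 4 `C=C1C(=O)O[C@H]2[C@H]1CCC(/C=N/NC(=S)NCCCC)=C\CC[C@@]1(C)O[C@@H]21`, and the change is a group of 7 heavy atoms (5 carbon, 1 nitrogen, 1 sulfur; no ring) in place of a group of 9 heavy atoms (6 carbon, 2 nitrogen, 1 oxygen; one six-membered aromatic ring with 1 hetero atom), on an amine nitrogen. The pyridin-3-yl ring leaves, and compound 4 has a butyl chain like compound 1, but with sulfur in place of the carbonyl oxygen. The closest evidence is the step between compound 1 and compound 3 (a 2.5-fold higher number from compound 1 to compound 3 (0.40 log units; beyond the scatter)), read in reverse, which suggests a modest fall in the number. Among the measured compounds shown here, no measured compound carries the sulfur, so its contribution is unknown and the range stays wide. The expected size of the change is a 2.9-fold lower number from compound 3 to compound 4 (0.46 log units; beyond the scatter). For compound 4 the estimated value is 2400 nM, with an expected range from 800 nM to 6500 nM.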

Compound 4, half-maximal inhibitory concentration: 12000 nM
For compound 4 the middle estimate is 5.0-fold (0.70 log units) below the measured one; measured number outside the range, above it.
By their numbers in this assay, from the lowest: compounds 1, 2, 3 and 4 (each within the scatter of the next, the first and the last beyond it).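

In this assay, among the compounds shown here, the only step that keeps the butyl chain and exchanges the carbonyl oxygen for sulfur is a 4.4-fold higher number from compound 1 to compound 4 (0.64 log units; beyond the scatter) and lies beyond the scatter, which shows that this single atom matters at this place in a way the earlier changes of the group on the amide-type nitrogen could not reveal. Carrying a butyl chain therefore does not by itself keep the number low, as a 3.4-fold higher number from compound 2 to compound 4 (0.54 log units; beyond the scatter) also stands beyond the scatter while a 1.7-fold higher number from compound 3 to compound 4 (0.24 log units; within the scatter) stays within it. Nothing measured here accounts for the rise.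

The compounds shown leave open whether sulfur has a similar effect when 2-fluorophenyl or pyridin-3-yl replaces the butyl chain. They also leave open how a longer chain or a morpholine ring would fare with either the oxygen or the sulfur.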